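A Sulfonamide Swap on a Weak Triazole Antiproliferative

This account rests on a few compounds, and the source may have more. Where it says the series, first, only, none or still open, it means among the compounds named here.

Compound 1 `O=C1O[C@H]([C@@H](O)Cn2cc(-c3cccc(O)c3)nn2)C(OCc2ccccc2)=C1OCc1ccccc1` gives 42900 nM in a functional assay on HCT-116 cells (Homo sapiens) for antiproliferative activity, read by MTT assay, with a stated time of 72 h (on this read-out higher numbers stand for weaker inhibition and lower numbers for stronger inhibition), the only numeric result among the three measured compounds. Compound 2 `CCCCCc1ccc(-c2cn(C/C=C3\OC(=O)C(OCc4ccccc4)=C3OCc3ccccc3)nn2)cc1` reaches only the limit of > 100000 nM. Compound 3 `O=C1O/C(=C\Cn2cc(-c3cc(C(F)(F)F)cc(C(F)(F)F)c3)nn2)C(OCc2ccccc2)=C1OCc1ccccc1` likewise stops at the limit of > 100000 nM. The picture is dominated by the limit of > 100000 nM in this assay, at which 2 of the 3 values shown sit, so compound 1 stands alone as the compound with a number. Compound 4 `O=C1O[C@H]([C@@H](O)Cn2cc(CNS(=O)(=O)c3ccc(F)cc3)nn2)C(OCc2ccccc2)=C1OCc1ccccc1` differs from compound 1 by (((4-fluorophenyl)sulfonyl)amino)methyl in place of 3-hydroxyphenyl on an aromatic carbon; in words, (((4-fluorophenyl)sulfonyl)amino)methyl in place of 3-hydroxyphenyl on an aromatic carbon. Among the measured compounds shown here, no measured pair shows a single change of this kind, so a 1.2-fold higher number from compound 1 to compound 4 (0.07 log units; within the scatter) is expected to be none beyond the scatter. Compound 4 is therefore estimated at 50000 nM, within 15000 nM to 150000 nM.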

Compound 4, half-maximal inhibitory concentration: 22900 nM
Compound 4: the middle estimate sits 2.2-fold (0.34 log units) above what was measured; the range from low to high includes it.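

At this aromatic carbon of the five-membered aromatic ring with 3 nitrogen, (((4-fluorophenyl)sulfonyl)amino)methyl in place of 3-hydroxyphenyl gives, in this assay, a 1.9-fold lower number from compound 1 to compound 4 (0.27 log units; within the scatter). This single change shows that the 3-hydroxyphenyl group is not required for the activity of compound 1, since a quite different group at this position keeps the value within the scatter.

On these data alone, whether an amine, a carboxylic acid or a longer chain in this place would move the value beyond the scatter stays open. Numeric values also remain few: the limit of > 100000 nM in this assay, at which 2 of the 4 values shown sit.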